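The source may hold more compounds than are shown below. What is called first, only, known or untested is meant among the compounds shown, and "the series" means these compounds.

Compound 1, `Oc1ccc(O)c(COCc2cc(O)ccc2O)c1`, gives 57300 nM in a functional assay on Bel-7402 cells (Homo sapiens) for cytotoxicity, read by sulforhodamine B assay; a higher number here means a weaker inhibitor, a lower number a stronger inhibitor.
Compound 2, `OCc1cc(OCc2cc(O)ccc2O)cc(Cl)c1O`, gives 38500 nM in this assay.
Compound 3, `COCc1cc(O)c(Cc2cc(O)ccc2O)cc1O`, gives 61900 nM in this assay.

Among these three numbers compound 3 has the highest, but its gaps to compound 1 and compound 2 both lie within the scatter, so the three compounds cannot be told apart here. Compound 4, `COCc1cc(O)c(Cc2cc(O)c(Cc3cc(O)ccc3O)cc2O)cc1O`, has not yet been measured in this assay. It differs from compound 3 by 2,5-dihydroxybenzyl in place of hydrogen on an aromatic carbon. For the measured compounds named here, no measured pair shows a change of this kind, so the data give no direct guide. The number is expected to move little, with at most a modest shift toward a lower number, hardly beyond the scatter. Compound 4 is therefore estimated at 35000 nM, between 12000 nM and 100000 nM. This amounts to an expected step of a 1.8-fold lower number from compound 3 to compound 4 (0.25 log units; within the scatter).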

Compound 4, half-maximal inhibitory concentration: 57000 nM
Estimate against measurement, compound 4: 1.6-fold (0.21 log units) below; low and high end bracket the measured number.
By their numbers in this assay, from the lowest: compounds 2, 4, 1 and 3 (each within the scatter of the next).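

In this assay putting 2,5-dihydroxybenzyl in place of hydrogen gives a 1.1-fold lower number from compound 3 to compound 4 (0.04 log units; within the scatter) and leaves the two compounds impossible to tell apart. For the compounds shown here, this aromatic carbon, ortho to a hydroxy group, therefore carries a whole extra aromatic ring with no readable difference in the number, something no earlier compound could show. No other data here speak to what lies behind this result.

Going by these compounds, whether a small group such as methyl, an amine or a carboxylic acid at this carbon would read the same remains open. So does whether 2,5-dihydroxybenzyl would behave alike elsewhere on the shared core.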